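The compounds below may be only part of what the source reports. "The series", "measured", "known", "first", "only" and "open" are said of these compounds alone.

Working notes on the series. Three compounds have results so far in a functional assay on HepG2 cells (Homo sapiens) for cytotoxicity, read by sulforhodamine B assay, with a stated time of 48 h (a lower number here means a stronger inhibitor, a higher number a weaker inhibitor), and two of them carry numbers. Compound 1 (`C/C(=N/NC(=O)C(C#N)C(=S)S)c1ccc(NS(=O)(=O)c2ccc(C)cc2)cc1`) gives 11000 nM there, and compound 3 (`Cc1ccc(S(=O)(=O)Nc2ccc(-c3cc(-c4ccc([N+](=O)[O-])cc4)n(C(=S)NN)n3)cc2)cc1`) gives 45300 nM on the same read-out. Compound 2 (`Cc1ccc(S(=O)(=O)Nc2ccc(C(=O)/C=C/c3ccccc3)cc2)cc1`) stands apart: it is reported as "not active" (no number reported) with no number attached, so it offers no numeric starting point.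

Compound 4 (`Cc1ccc(S(=O)(=O)Nc2ccc(C(=O)/C=C/c3ccc(Cl)cc3)cc2)cc1`) is still unmeasured. The structural change from compound 2 is chloro in place of hydrogen on an aromatic carbon; in words, chloro in place of hydrogen on an aromatic carbon, which turns phenyl into 4-chlorophenyl. Among the measured compounds shown here, no measured step covers this change, so any expectation for this assay is loose. A modest shift towards stronger inhibition is expected, with the result staying in the region of compound 3 at 45300 nM in this series, and a second report without a number remains quite possible. Compound 4 is expected at 40000 nM with a range from 12000 nM to 100000 nM as the working estimate.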

Compound 4, half-maximal inhibitory concentration: 43300 nM
Compound 4: middle estimate off by 1.1-fold (0.03 log units), on the low side, within the range that was stated.
By their numbers in this assay, from the lowest: compound 1; then compounds 4 and 3 (each within the scatter of the next).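

Among the compounds shown here, compound 2 carries no number in this assay, so the change from phenyl to 4-chlorophenyl in compound 4 gives no step that can be read. The compounds shown leave open what size of shift, if any, this change produces. No supporting data bear on this result.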